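Swapping one aryl ring for another on a shared biphenyl-like core

A few compounds are considered here, and "the series" means these few. Any claim that something is new, unique, unknown or untested is made for them only; others in the source may bear on it.

Of the compounds shown here, two with the same core have been measured so far in a functional assay for agonist activity at G protein-coupled receptor 88 (Homo sapiens), read by HTRF and cAMP accumulation; a higher number here means that more compound is needed for the effect, a lower number that less compound is needed. Compound 1, `CC(C)C[C@H](N)CN(C(=O)[C@@H]1C[C@H]1c1ccccc1)c1ccc(-c2ccoc2)cc1`, gives 2000 nM. Compound 2, `Cc1cccc(-c2ccc(N(C[C@@H](N)CC(C)C)C(=O)[C@@H]3C[C@H]3c3ccccc3)cc2)c1`, gives 1200 nM. Among the compounds with values here, the only change between them is a 3-methylphenyl in place of a furan-3-yl on an aromatic carbon, and the step of a 1.7-fold lower number from compound 1 to compound 2 (0.22 log units; within the scatter) stays inside the usual scatter of repeated measurements. Compound 2 therefore holds the lowest of the two numbers, but its nearest neighbour, compound 1, lies within the scatter of it, so no ordering can be claimed.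

Compound 3, `CC(C)C[C@H](N)CN(C(=O)[C@@H]1C[C@H]1c1ccccc1)c1ccc(-c2ccc(F)cc2)cc1`, takes the next step at the same position: 4-fluorophenyl in place of 3-methylphenyl on an aromatic carbon. Within the data shown here, the one measured step that bears on this kind of exchange, an aryl group replacing another at this aromatic carbon, is the step from compound 1 to compound 2, and it was small. A step of similar size, in either direction or none beyond the scatter, is expected here, written as a 1.3-fold higher number from compound 2 to compound 3 (0.10 log units; within the scatter). Compound 3 is estimated to give 1500 nM in this assay, with a range from 500 nM to 4500 nM.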

Compound 3, half-maximal effective concentration: 900 nM
The estimate for compound 3 lay 1.7-fold (0.22 log units) above the measured number, within the range that was stated.
By their numbers in this assay, from the lowest: compounds 3, 2 and 1 (each within the scatter of the next, the first and the last beyond it).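

In this assay, the exchange of 3-methylphenyl for 4-fluorophenyl gives (a 1.3-fold lower number from compound 2 to compound 3 (0.12 log units; within the scatter)), so at this position, on an aromatic carbon para to a large group, these two rings cannot be told apart, even though one carries a methyl group and the other a fluorine. Within the data shown here, the exchange of furan-3-yl for 4-fluorophenyl gives (a 2.2-fold lower number from compound 1 to compound 3 (0.35 log units; beyond the scatter)), which is the first step at this position to pass the scatter, though only modestly, and compound 2 cannot be separated from either of the other two compounds. Nothing measured alongside these numbers explains that difference.

The compounds shown leave open what plain phenyl, with neither methyl nor fluorine, would give at this carbon, and so whether either substituent matters at all. They also leave open whether this carbon can carry something other than an aromatic ring, such as an amine, a carboxylic acid or a longer chain, and whether any such group would move the number further than these three rings do.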